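Removing One Trifluoromethyl: A Single-Change Step

The compounds below may be only part of what the source reports. "The series", "measured", "known", "first", "only" and "open" are said of these compounds alone.

Of the compounds shown here, two have been tested in a functional assay on A498 cells (Homo sapiens) for inhibition, read by sulforhodamine B assay, with a stated time of 48 h, tested at 0.1 uM; a higher number here means a weaker effect of the compound at the concentration tested, a lower number a stronger effect. Compound 1 `O=C(Nc1cccc(-n2cc(-c3ccncc3)c(-c3cc(O)cc(Cl)c3)n2)c1)Nc1ccc(Cl)c(Cl)c1` gives 94%, so at this concentration it leaves most of the cell growth untouched. Compound 2 `COc1cc(Cl)cc(-c2nn(-c3cccc(NC(=O)Nc4cc(C(F)(F)F)cc(C(F)(F)F)c4)c3)cc2-c2ccncc2)c1` gives 69%, which is the lower of the two numbers and stands a clear distance below compound 1, beyond the usual scatter. The two structures differ in several places at once, so no single change can be credited for that gap.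

Compound 3 `COc1cc(Cl)cc(-c2nn(-c3cccc(NC(=O)Nc4cccc(C(F)(F)F)c4)c3)cc2-c2ccncc2)c1` is the next step from compound 2, and it differs in exactly one way: hydrogen in place of trifluoromethyl on an aromatic carbon. For the measured compounds named here, with no measured pair showing what such a removal does here, the outlook rests on compound 2 alone and is expected to be a moderate loss of effect, a shift of a number 11 percentage points higher from compound 2 to compound 3 (beyond the scatter) toward a higher number in this assay. Compound 3 is therefore estimated at 80%, within a range from 62% to 98%.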

Compound 3, a percentage reported as activity, at one concentration (the size of the read-out at that concentration, not a potency): 92%
The estimate for compound 3 lay 12 percentage points below the measured number; low and high end bracket the measured number.
By their numbers in this assay, from the lowest: compound 2; then compounds 3 and 1 (each within the scatter of the next).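

In this assay, for the compounds shown here, the change of hydrogen in place of trifluoromethyl gives a number 23 percentage points higher from compound 2 to compound 3 (beyond the scatter), the first measured step here in which only one thing changes. It shows that this trifluoromethyl, on a ring carbon meta to a large group and meta to a trifluoromethyl group, contributes to the effect of compound 2 at the one concentration tested, since the rest of the structure stays the same. Nothing measured here explains why this group counts at this position.

Going by these compounds, whether a smaller group such as methyl, or a nitrile, could replace the trifluoromethyl at this position and keep the effect remains open. Going by these compounds alone, it is also open whether the same change would have the same size on a different core, since only this one pair shows it.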